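Cyclopentyl to Pyridin-2-yl: Tolerability Expected to Hold

The compounds below may be only part of what the source reports. "The series", "measured", "known", "first", "only" and "open" are said of these compounds alone.

Compound 2 `COc1ccc(-c2cnc(NC(=O)C3CCCC3)n2C)cc1` and compound 1 `COc1ccc(-c2cnc(NC(=O)c3ccc(F)cc3)n2C)cc1` share one core and differ only in the group on the carbonyl carbon. In a toxicity assay on THP-1 cells (Homo sapiens) for inhibition (a higher number here means that more compound is tolerated, a lower number that less compound is tolerated), compound 1 gives >= 50000 nM, which is a limit of the assay rather than a number. In this assay compound 2 gives > 100000 nM, again a limit of the assay. The step that the two limits leave unreadable from compound 1 to compound 2 therefore cannot be read in size, since both values sit at limits (the limit of > 100000 nM in this assay, at which 1 of the 2 values shown sits, (the limit of >= 50000 nM in this assay, at which 1 of the 2 values shown sits)). Compound 3 `COc1ccc(-c2cnc(NC(=O)c3ccccn3)n2C)cc1` differs from compound 2 by pyridin-2-yl in place of cyclopentyl on a carbonyl carbon. Among the compounds with values here, no readable measured step bears on this change; the only related step, that between compound 1 and compound 2, is unreadable. Compound 3 is therefore expected to remain near the limit, with an expected step of a number no higher from compound 2 to compound 3 (the limit leaves the size open) that stays within the scatter. Compound 3 is estimated at 100000 nM in this assay, within 30000 nM to 300000 nM.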

Compound 3, half-maximal cytotoxic concentration: > 100000 nM
Compound 3 ended at the assay's limit; the forecaster's own chance of this, stated with the estimate: 70%; the middle value lies on the limit itself.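

In this assay compound 3 gives > 100000 nM, which is a limit of the assay and not a number. The steps among compound 1, compound 2 and compound 3 therefore cannot be read. The compounds shown leave open whether the group on the carbonyl carbon affects tolerance at all.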